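The source may hold more compounds than are shown below. What is called first, only, known or untested is meant among the compounds shown, and "the series" means these compounds.

Compound 3 `CCOC(=O)c1cnn(-c2nc(-c3ccc(OC)cc3)c(C#N)c(=O)n2C)c1N` gives 59 ug/mL in a functional assay, with a stated time of 20 min; on this read-out higher numbers stand for weaker inhibition and lower numbers for stronger inhibition. Compound 1 `COc1ccc(-c2nc(SC)n(C)c(=O)c2C#N)cc1` gives 58 ug/mL and compound 2 `COc1ccc(-c2nc(NN)n(C)c(=O)c2C#N)cc1` gives 41 ug/mL; all three numbers lie within the usual scatter of one another, so compound 3 is not set apart from either neighbour. Compound 4 `CCOC(=O)c1cnn(-c2nc(-c3ccccc3F)c(C#N)c(=O)n2C)c1N` differs from compound 3 by 2-fluorophenyl in place of 4-methoxyphenyl on an aromatic carbon. Going by the values given here, the only measured step, a 1.4-fold lower number from compound 1 to compound 2 (0.15 log units; within the scatter), alters a different position of the shared core and bears on the aryl group only indirectly, and none of the three numbers distinguishes one aryl group from another. No step beyond the scatter is therefore expected, no change at the digits printed from compound 3 to compound 4 (within the scatter). The estimate for compound 4 is 59 ug/mL, with a range from 25 ug/mL to 140 ug/mL.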

Compound 4, half-maximal inhibitory concentration: 69 ug/mL
For compound 4 the middle estimate is 1.2-fold (0.07 log units) below the measured one; the range from low to high includes it.
By their numbers in this assay, from the lowest: compounds 2, 1, 3 and 4 (each within the scatter of the next).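

In this assay, going by these compounds alone, 2-fluorophenyl in place of 4-methoxyphenyl gives a 1.2-fold higher number from compound 3 to compound 4 (0.07 log units; within the scatter), the only step read at this position. The two aryl groups therefore cannot be told apart on this read-out, even though they differ both in the substituent and in where it sits on the phenyl ring. No measurement at hand offers an explanation for this result. From the compounds shown here alone, it remains open whether an unsubstituted phenyl, a phenyl carrying an amine or a carboxylic acid, or a saturated ring such as cyclohexyl at this position would give a step beyond the scatter.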